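Chloro-to-hydrogen step on the pendant phenyl, thiourea core

The source may report more compounds than this note shows. Statements on the series, on what has been measured and on what is new or still open speak of the compounds shown alone.

Of the compounds shown here, three have been measured in a functional assay, with a stated time of 20 min, tested at 20 uM; on this read-out higher numbers stand for a stronger effect at the one concentration tested and lower numbers for a weaker effect. Compound 1, `COc1cc(/C=C/C(=O)C2=C(/C=C/c3ccc(O)c(OC)c3)NC(=O)NC2c2ccccc2)ccc1O`, gives 38.2%. Compound 2, `COc1cc(/C=C/C(=O)C2=C(/C=C/c3ccc(O)c(OC)c3)NC(=O)NC2c2ccccc2Cl)ccc1O`, gives 46%. Compound 3, `COc1cc(/C=C/C(=O)C2=C(/C=C/c3ccc(O)c(OC)c3)NC(=S)NC2c2c(Cl)cccc2Cl)ccc1O`, gives 43.2%. The difference between the cores of compound 2 and compound 3 is not broken down here; their two values lie within the scatter of each other, as do those of compound 3 and compound 1.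

One change is measured directly: hydrogen in place of chloro on an aromatic carbon gives a number 7.8 percentage points lower from compound 2 to compound 1 (within the scatter), a step within the scatter.

Compound 4, `COc1cc(/C=C/C(=O)C2=C(/C=C/c3ccc(O)c(OC)c3)NC(=S)NC2c2ccccc2Cl)ccc1O`, remains to be measured in this assay. It stands to compound 3 as compound 1 stands to compound 2: hydrogen in place of chloro on an aromatic carbon. The place is not the same word for word; in compound 3 the position is ortho to a large group and also meta to a chloro group, whereas in compound 2 it is only ortho to a large group, so this is the same kind of change rather than the same change.

For compound 4 the expected step is a number 5.2 percentage points lower from compound 3 to compound 4 (within the scatter), a step estimated to be small, because the same kind of change from compound 2 to compound 1 gave a number 7.8 percentage points lower from compound 2 to compound 1 (within the scatter). Compound 4 is therefore expected to give about 38%, with a range estimated from 28% to 48%.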

Compound 4, a percentage reported as activity, at one concentration (the size of the read-out at that concentration, not a potency): 56.6%
Compound 4: middle estimate off by 18.6 percentage points, on the low side; the measured number lies above the stated range.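

In this assay, the exchange of chloro for hydrogen on the pendant phenyl does not carry over from one core to the other as a fixed increment, and the direction of the printed steps is not shared: the same change on two cores in this assay, a number 7.8 percentage points lower (within the scatter) from compound 2 to compound 1 and a number 13.4 percentage points higher (beyond the scatter) from compound 3 to compound 4, 21.2 percentage points apart, beyond the scatter of two such steps

The new step, a number 13.4 percentage points higher from compound 3 to compound 4 (beyond the scatter), is 2,6-dichlorophenyl to 2-chlorophenyl, with the exchanged position ortho to a large group and meta to a chloro group, whereas a number 7.8 percentage points lower from compound 2 to compound 1 (within the scatter) removes the only chloro on that ring. The two pairs therefore differ both in the core and in the surroundings of the exchanged position, so they show that the earlier step cannot be transferred unchanged but do not show which of these two differences accounts for the gap, and two pairs establish no rule for the series.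

The compounds shown leave open how an unsubstituted phenyl behaves on the core of compound 4 and how 2,6-dichlorophenyl behaves on the core of compound 1, the two comparisons that would separate the core from the chloro count. Also open, going by these compounds, is whether another group at that position, such as fluoro, methoxy or a carboxylic acid, would follow either step.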